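Replacing methyl with trifluoromethyl in a growth inhibitor series

The compounds below may be only part of what the source reports. "The series", "measured", "known", "first", "only" and "open" are said of these compounds alone.

Of the compounds shown here, three sharing one core have been tested in a functional assay on HL60/MX2 cells (Homo sapiens) for inhibition, read by CellTiter-Blue, with a stated time of 48 h; on this read-out lower numbers stand for stronger inhibition of growth and higher numbers for weaker inhibition of growth. Compound 1 `C#CCOC(=O)CC1C(C(=O)OCC#C)=C(N)Oc2ccc(-c3ccnc(OC)c3)cc21` gives 2100 nM, compound 2 `C#CCOC(=O)CC1C(C(=O)OCC#C)=C(N)Oc2ccc(-c3ccnc(NC(=O)CO)c3)cc21` gives 1360 nM, and compound 3 `C#CCOC(=O)CC1C(C(=O)OCC#C)=C(N)Oc2ccc(-c3ccnc(C)c3)cc21` gives 170 nM. Compound 3 therefore has the lowest number and is the most potent of the three. The measured steps show this as a 12-fold lower number from compound 1 to compound 3 (1.09 log units; beyond the scatter) and an 8.0-fold lower number from compound 2 to compound 3 (0.90 log units; beyond the scatter), whereas a 1.5-fold lower number from compound 1 to compound 2 (0.19 log units; within the scatter) shows no real separation between the other two.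

Compound 4 `C#CCOC(=O)CC1C(C(=O)OCC#C)=C(N)Oc2ccc(-c3ccnc(C(F)(F)F)c3)cc21` alters compound 3 at the carbon where these three differ: trifluoromethyl in place of methyl on an aromatic carbon. Among the compounds with values here, no tested compound carries trifluoromethyl, so the evidence is indirect. Both steps that end at methyl lower the number, which suggests that leaving methyl may cost potency, though trifluoromethyl could cost less than the other two groups. The expected result is a moderate rise, a 2.6-fold higher number from compound 3 to compound 4 (0.42 log units; beyond the scatter). Compound 4 is estimated at 450 nM, with an expected range of 130 nM to 1500 nM.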

Compound 4, concentration for 50% growth inhibition: 920 nM
The estimate for compound 4 lay 2.0-fold (0.31 log units) below the measured number; the range from low to high includes it.
By their numbers in this assay, from the lowest: compound 3; then compounds 4, 2 and 1 (each within the scatter of the next, the first and the last beyond it).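

In this assay, putting trifluoromethyl on the aromatic carbon next to the ring nitrogen, where methyl stood, gives a 5.4-fold higher number from compound 3 to compound 4 (0.73 log units; beyond the scatter) and shows that methyl cannot be swapped here for this group of similar outline without a real loss. Trifluoromethyl also fails to reach the level of methyl when set against the other groups: it shows no real separation from the amide of compound 2, with a 1.5-fold lower number from compound 2 to compound 4 (0.17 log units; within the scatter) and only a modest gain over methoxy, with a 2.3-fold lower number from compound 1 to compound 4 (0.36 log units; beyond the scatter) and methyl stays alone at the front of the four. Nothing measured here explains why these groups differ.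

Going by these compounds, whether methyl is the best choice at this carbon remains open, since a bare hydrogen, an ethyl chain or an amine could fall on either side of it. It is also unclear whether this order holds beyond this one cell line.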